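This account rests on a few compounds, and the source may have more. Where it says the series, first, only, none or still open, it means among the compounds named here.

Compound 1 `CCn1nc(-c2ccc(OC)cc2)c(-c2ccc(OC)cc2)cc1=O`: 610 nM
Compound 2 `COc1ccc(-c2cc(=O)n(CC(C)C)nc2-c2ccc(OC)cc2)cc1`: > 100000 nM
Compound 3 `COc1ccc(-c2cc(=O)n(CC3CC3)nc2-c2ccc(OC)cc2)cc1`: 1800 nM

In a functional assay on HL-60 cells (Homo sapiens) for inhibition (a lower number here means a stronger inhibitor, a higher number a weaker inhibitor), compound 1 gives 610 nM and compound 3 gives 1800 nM. For compound 2 the reading of > 100000 nM is a limit of the assay and not a number (the limit of > 100000 nM in this assay, at which 1 of the 3 values shown sits). Compound 4 `COc1ccc(-c2cc(=O)n(C3CCCC3)nc2-c2ccc(OC)cc2)cc1` has not been measured; it differs from compound 2 by cyclopentyl in place of isobutyl on an aromatic nitrogen. Among the compounds with values here, two measured steps bear on this change: an at least 160-fold higher number from compound 1 to compound 2 (2.21 log units; beyond the scatter) and an at least 55-fold lower number from compound 2 to compound 3 (1.74 log units; beyond the scatter). The isopropyl branch cost nearly all activity, while the cyclopropyl ring recovered most of it. A five-membered ring on the aromatic nitrogen lies between these cases, so a fall in the number from compound 2 is expected, though with wide uncertainty. Compound 4 is estimated at 20000 nM, between 2000 nM and 100000 nM, which means an expected at least 5.0-fold lower number from compound 2 to compound 4 (0.69 log units; beyond the scatter).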

Compound 4, half-maximal inhibitory concentration: 510 nM
Compound 4: the middle estimate sits 39-fold (1.59 log units) above what was measured; the whole stated range lies above it.
By their numbers in this assay, from the lowest: compounds 4 and 1 (each within the scatter of the next); then compound 3. At a limit, above all of these: compound 2.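

Compound 2 stands at a limit of the assay and not at a number: the limit of > 100000 nM in this assay, at which 1 of the 4 values shown sits. Cyclopentyl gives an at least 190-fold lower number from compound 2 to compound 4 (2.29 log units; beyond the scatter) and a 3.5-fold lower number from compound 3 to compound 4 (0.55 log units; beyond the scatter), while a 1.2-fold lower number from compound 1 to compound 4 (0.08 log units; within the scatter). So the number of heavy atoms alone does not decide activity at this position: cyclopentyl, with more heavy atoms than isobutyl, is on a par with ethyl, whereas isobutyl loses activity. Whether cyclohexyl or a chain ending in an amine would keep this activity stays open, and the compounds shown do not explain why isobutyl stands apart.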